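Cyanophenyl Position on Urea and Thiourea Analogues

The source may report more compounds than this note shows. Statements on the series, on what has been measured and on what is new or still open speak of the compounds shown alone.

Compound 1 `CCS(=O)(=O)Nc1ccc2c(c1)C(NC(=S)Nc1cccc(C#N)c1)CC(C)(C)O2` and compound 2 `CCS(=O)(=O)Nc1ccc2c(c1)C(NC(=S)Nc1ccc(C#N)cc1)CC(C)(C)O2` share a thiourea-bearing core. In a functional assay on thoracic aorta (Rattus norvegicus) for inhibition (a lower number here means that less compound is needed, a higher number that more compound is needed for the effect), compound 1 gives 12100 nM, and compound 2 gives 12000 nM. The change 4-cyanophenyl in place of 3-cyanophenyl on an amide-type nitrogen thus produced a 1.0-fold lower number from compound 1 to compound 2 (0.00 log units; within the scatter). Compound 3 `CCS(=O)(=O)Nc1ccc2c(c1)C(NC(=O)Nc1cccc(C#N)c1)CC(C)(C)O2` carries a urea in place of the thiourea; the difference between the cores of compound 1 and compound 3 is not broken down here. In this assay compound 3 gives 9500 nM. Compound 4 `CCS(=O)(=O)Nc1ccc2c(c1)C(NC(=O)Nc1ccc(C#N)cc1)CC(C)(C)O2` is not yet measured. The change 4-cyanophenyl in place of 3-cyanophenyl on an amide-type nitrogen is the same kind of change as from compound 1 to compound 2, but here the amide-type nitrogen sits next to a carbonyl carbon rather than a thiocarbonyl carbon. Because a 1.0-fold lower number from compound 1 to compound 2 (0.00 log units; within the scatter) lay within the scatter, compound 4 is expected to show no change at the digits printed from compound 3 to compound 4 (within the scatter). Compound 4 is estimated at 9500 nM, between 5000 nM and 18000 nM.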

Compound 4, half-maximal effective concentration: 11800 nM
For compound 4 the middle estimate is 1.2-fold (0.09 log units) below the measured one; measured number inside the range.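

In this assay, 4-cyanophenyl in place of 3-cyanophenyl on an amide-type nitrogen whose other neighbour is a carbonyl carbon gave a 1.2-fold higher number from compound 3 to compound 4 (0.09 log units; within the scatter). Set beside the same change on the thiourea core, the two steps do not differ: the same change on two cores in this assay, a 1.0-fold lower number (0.00 log units; within the scatter) from compound 1 to compound 2 and a 1.2-fold higher number (0.09 log units; within the scatter) from compound 3 to compound 4, 1.3-fold (0.10 log units) apart, within the scatter of two such steps. This shows that on these two cores the change leaves the number within the scatter, but it does not show that the same would hold on any other core, nor does a change that stays within the scatter on both reveal how large a real effect could carry over.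

The compounds shown leave open how the number responds when a plain phenyl, a pyridyl or a carboxylic acid-bearing phenyl stands in place of the cyanophenyl group. They also leave open whether a longer chain in place of the ethyl on the sulfonyl group would alter the result.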